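The source may hold more compounds than are shown below. What is called first, only, known or untested is meant among the compounds shown, and "the series" means these compounds.

Compound 1 `CC[C@H](NC(=O)c1c(CN2CCN(C(C)C)CC2)c(-c2ccccc2)nc2ccccc12)c1ccccc1` is the weaker of the two measured entries: in an assay on cell membranes for displacement of a labelled ligand from Substance-K receptor (Homo sapiens) (on this read-out lower numbers stand for stronger inhibition and higher numbers for weaker inhibition), compound 1 gives 5.7 nM. Compound 2 `CC[C@H](NC(=O)c1c(CN2CCN(C3CCCCC3)CC2)c(-c2ccccc2)nc2ccccc12)c1ccccc1` gives 1.6 nM in this assay, and the step of a 3.6-fold lower number from compound 1 to compound 2 (0.55 log units; beyond the scatter) concerns cyclohexyl in place of isopropyl on an amine nitrogen in a ring. Compound 3 `CC(C)NC(=O)c1c(CN2CCN(C(C)C)CC2)c(-c2ccccc2)nc2ccccc12` is not yet measured. It differs from compound 1 by isopropyl in place of 1-phenylpropyl on an amide-type nitrogen. Going by the values given here, no measured step touches the amide-type nitrogen; the only step known, from compound 1 to compound 2, changes the amine nitrogen in a ring and so gives no direct guide. The change removes a six-membered aromatic ring and the defined stereocentre, a larger alteration than the one measured, and the expected direction is toward a higher number with wide uncertainty. For compound 3 the expected value in this assay is 400 nM, within 40 nM to 4000 nM, which is an expected step of a 70-fold higher number from compound 1 to compound 3 (1.85 log units; beyond the scatter).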

Compound 3, inhibition constant: 811 nM
Beside the measured number, compound 3's estimate is 2.0-fold (0.31 log units) below it; low and high end bracket the measured number.
By their numbers in this assay, from the lowest: compound 2; then compound 1; then compound 3.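

In this assay, isopropyl in place of 1-phenylpropyl on the amide-type nitrogen gives a 140-fold higher number from compound 1 to compound 3 (2.15 log units; beyond the scatter), a far larger step than a 3.6-fold lower number from compound 1 to compound 2 (0.55 log units; beyond the scatter) at the amine nitrogen in a ring. Among the steps read so far, the amide-type nitrogen is therefore the place where a change moves the number most, and the 1-phenylpropyl group is strongly favoured over isopropyl there. No measurement on hand explains the size of this step.

The change removes a six-membered aromatic ring and a defined stereocentre together, so the share of each remains unresolved; a benzyl or 1-cyclohexylpropyl group on the amide-type nitrogen would separate the two. Also open, on these data alone, is whether cyclohexyl in place of isopropyl on the amine nitrogen in a ring would give a similar step with isopropyl on the amide-type nitrogen.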